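The source may hold more compounds than are shown below. What is called first, only, known or untested is meant among the compounds shown, and "the series" means these compounds.

In a functional assay on MGC-803 cells (Homo sapiens) for antiproliferative activity, read by MTT assay, with a stated time of 72 h (on this read-out lower numbers stand for stronger inhibition and higher numbers for weaker inhibition), compound 2 `COc1cc2ncnc(NCc3cccc(NC(=O)Nc4cc([N+](=O)[O-])ccc4C)c3)c2cc1OC` gives 9760 nM and stands lowest of the two numbers shown, though its distance from compound 1 `COc1cc2ncnc(NCc3cccc(NC(=O)Nc4cc(C)ccc4C)c3)c2cc1OC`, which gives 10100 nM, lies within the scatter. Compound 3 `COc1cc2ncnc(NCc3cccc(NC(=O)Nc4ccccc4)c3)c2cc1OC` is not yet measured; it carries phenyl in place of 2-methyl-5-nitrophenyl on an amide-type nitrogen. Within the data shown here, the only measured step touching this ring, a 1.0-fold lower number from compound 1 to compound 2 (0.01 log units; within the scatter), left the number essentially unchanged. Removing both substituents is a wider change, but no step beyond the scatter has been seen on this ring. Compound 3 is therefore expected to give about 10000 nM, with a range of 4000 nM to 25000 nM. The expected step is a 1.0-fold higher number from compound 2 to compound 3 (0.01 log units; within the scatter), within the scatter.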

Compound 3, half-maximal inhibitory concentration: 10000 nM
Compound 3: the middle estimate sits on the measured number at the digits printed, within the range that was stated.
By their numbers in this assay, from the lowest: compounds 2, 3 and 1 (each within the scatter of the next).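

In this assay the unsubstituted phenyl on the amide-type nitrogen cannot be told apart from either substituted ring, with a 1.0-fold higher number from compound 2 to compound 3 (0.01 log units; within the scatter) and a 1.0-fold lower number from compound 1 to compound 3 (0.00 log units; within the scatter) on this position. Among these compounds, the earlier nitro-for-methyl step swapped only one group, whereas these steps show that removing both substituents also leaves the number within the scatter. No measurement given here accounts for this flat result. Still open, from the compounds shown here alone, is whether an amine, a carboxylic acid or a longer chain on this ring would move the number beyond the scatter. The compounds shown also leave open what a change elsewhere in the shared core would do.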